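Cyano for fluoro at the aniline: expected cytotoxicity

The compounds below may be only part of what the source reports. "The series", "measured", "known", "first", "only" and "open" are said of these compounds alone.

Compound 2 `Fc1ccc(NCCNc2ccnc3cc(Cl)ccc23)cc1` is one of two measured compounds in the series. In a toxicity assay on Huh-7 cells (Homo sapiens) for cytotoxicity, read by MTT assay, with a stated time of 72 h (a higher number here means that more compound is tolerated, a lower number that less compound is tolerated), compound 2 gives > 100 ug/mL, a limit of the assay rather than a number. Compound 1 `COc1ccc(NCCNc2ccnc3cc(Cl)ccc23)cc1` gives > 100 ug/mL in this assay, also a limit. Among the compounds with values here, the step that the two limits leave unreadable from compound 1 to compound 2 is therefore unreadable, and the limit of > 100 ug/mL in this assay, at which 2 of the 2 values shown sit, is the only evidence available. Compound 3 `N#Cc1ccc(NCCNc2ccnc3cc(Cl)ccc23)cc1` differs from compound 2 by cyano in place of fluoro on an aromatic carbon. Within the data shown here, no measured step bears on this change. Compound 3 is expected to stay at the limit, with the step that the limit leaves unreadable from compound 2 to compound 3 expected to be within the scatter. The estimate for compound 3 is 150 ug/mL, from 60 ug/mL to 500 ug/mL.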

Compound 3, half-maximal cytotoxic concentration: 39.6 ug/mL
Estimate against measurement, compound 3: 3.8-fold (0.58 log units) above; the measured number lies below the stated range.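

In this assay, cyano in place of fluoro gives an at least 2.5-fold lower number from compound 2 to compound 3 (0.40 log units; beyond the scatter), and cyano in place of methoxy gives an at least 2.5-fold lower number from compound 1 to compound 3 (0.40 log units; beyond the scatter). This position can therefore carry a group that brings the number off the limit, which neither fluoro nor methoxy showed. Both steps start from a limit, so their full size stays unknown: the limit of > 100 ug/mL in this assay, at which 2 of the 3 values shown sit.

The step between compound 1 and compound 2 cannot be read. On these data alone, whether trifluoromethyl or a carboxylic acid at this position would also lower the number remains open.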